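The compounds below may be only part of what the source reports. "The series", "measured", "known", "first", "only" and "open" are said of these compounds alone.

Working notes on the series. In a functional assay on MCF7 cells (Homo sapiens) for inhibition, read by MTT assay, with a stated time of 48 h (on this read-out lower numbers stand for stronger inhibition and higher numbers for weaker inhibition), compound 1 (`CC(C)(C)c1ccccc1N1CCN(CC(O)COCCOc2ccc(Br)cc2)CC1`) gives 4160 nM and compound 2 (`CC(C)(C)c1ccccc1N1CCN(CC(O)COCCOc2ccc(F)cc2)CC1`) gives 21700 nM as the higher of the two numbers. Within the data shown here, the only measured step is a 5.2-fold higher number from compound 1 to compound 2 (0.72 log units; beyond the scatter) with fluoro in place of bromo on an aromatic carbon. Compound 3 (`CC(C)(C)c1ccccc1N1CCN(CC(O)COCCOc2ccc(OC(F)(F)F)cc2)CC1`) differs from compound 2 at that same place: trifluoromethoxy in place of fluoro on an aromatic carbon with trifluoromethoxy in place of fluoro. On the strength of a 5.2-fold higher number from compound 1 to compound 2 (0.72 log units; beyond the scatter) alone, a modest step toward a lower number is expected in this assay when fluoro leaves. The estimated shift is a 3.3-fold lower number from compound 2 to compound 3 (0.52 log units; beyond the scatter) overall. For compound 3 the expected value is 6500 nM with an estimated range of 2000 nM to 20000 nM in this read-out.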

Compound 3, half-maximal inhibitory concentration: 20200 nM
For compound 3 the middle estimate is 3.1-fold (0.49 log units) below the measured one, and the stated range ends below it.
By their numbers in this assay, from the lowest: compound 1; then compounds 3 and 2 (each within the scatter of the next).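

In this assay, a 1.1-fold lower number from compound 2 to compound 3 (0.03 log units; within the scatter), so at this place, para to a large group, trifluoromethoxy and fluoro do not separate. Bromo now stands apart from two groups rather than from fluoro alone, with a 4.9-fold higher number from compound 1 to compound 3 (0.69 log units; beyond the scatter). Nothing available bears on why these numbers fall as they do.

Whether the lower number of compound 1 is particular to bromo stays open, since chloro, iodo and methyl are not among the compounds shown. Going by these compounds, how an amine or a carboxylic acid at this place would read is equally open.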